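A few compounds are considered here, and "the series" means these few. Any claim that something is new, unique, unknown or untested is made for them only; others in the source may bear on it.

In a toxicity assay on NIH3T3 cells (Mus musculus) for cytotoxicity, read by resazurin assay (on this read-out higher numbers stand for an effect only at larger amounts of compound and lower numbers for an effect already at smaller amounts), compound 3, `COC(=O)c1ccc(NCc2cncn2Cc2ccc(N)cc2)cc1-c1ccccc1`, shows only a limit, > 10000 nM. Compound 1, `Nc1cc(-c2ccccc2)ccc1Cn1cncc1CNc1ccc(Cl)c(-c2ccccc2)c1`, likewise reaches only a limit in this assay, > 1000 nM. Compound 2, `c1ccc(Cn2cncc2CNc2cccc(-c3ccccc3)c2)cc1`, also gives a limit in this assay, > 750 nM. All three values are thus limits rather than numbers, and compound 3 sits at the highest of them, (the limit of > 10000 nM in this assay, at which 1 of the 3 values shown sits). Compound 4, `COC(=O)c1ccc(NCc2cncn2Cc2ccc(C)cc2)cc1-c1ccccc1`, has not yet been measured; it differs from compound 3 in one place: methyl in place of amino on an aromatic carbon. Within the data shown here, no step between measured compounds is available in this assay, and with every value a limit, no direction can be read from them. Compound 4 is therefore expected to stay at a limit, with the expected step of a number no higher from compound 3 to compound 4 (the limit leaves the size open) none beyond the scatter. Compound 4 is estimated at 10000 nM, between 3000 nM and 30000 nM.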

Compound 4, half-maximal effective concentration: 50000 nM
The estimate for compound 4 lay 5.0-fold (0.70 log units) below the measured number; measured number outside the range, above it.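

Among these compounds, no step from compound 3 to compound 4 can be read in this assay: compound 3 gives only a limit. The compounds shown leave open how far methyl in place of amino on an aromatic carbon shifts the value.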